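Swapping the sulfonyl substituent in a pancreatic-cell growth inhibitor

The source may hold more compounds than are shown below. What is called first, only, known or untested is meant among the compounds shown, and "the series" means these compounds.

Three compounds share a core built around a sulfonylated piperidine carboxamide, and all were tested in a functional assay on BXPC-3 cells (Homo sapiens) for inhibition, read by MTT assay, with a stated time of 7 days; a lower number here means a stronger inhibitor, a higher number a weaker inhibitor. Compound 2 `O=C([C@@H]1CCCN(S(=O)(=O)c2ccc(S(=O)(=O)C3CCC3)cc2)C1)N1CCC(F)(F)CC1` gives 78 nM, the lowest of the three numbers. Compound 1 `CCN(CC)S(=O)(=O)c1ccc(S(=O)(=O)N2CCC[C@@H](C(=O)N[C@H]3CC[C@H](OC)CC3)C2)cc1` gives 2000 nM, and compound 3 `CCN(CC)S(=O)(=O)c1ccc(S(=O)(=O)N2CCC[C@@H](C(=O)NC3CCOCC3)C2)cc1` gives 8570 nM. Among the measured compounds shown here, the only single-point step among them, a 4.3-fold higher number from compound 1 to compound 3 (0.63 log units; beyond the scatter), concerns the amide side of the molecule.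

Compound 4 `CCN(CC)S(=O)(=O)c1ccc(S(=O)(=O)N2CCC[C@@H](C(=O)N3CCC(F)(F)CC3)C2)cc1` is compound 2 with one alteration on the other side: diethylamino in place of cyclobutyl on a sulfonyl sulfur. For the measured compounds named here, no measured pair isolates this change; compounds 1 and 3 carry the diethylsulfamoyl group but also differ from compound 2 in the amide, so their weaker numbers cannot be assigned to the sulfonyl substituent alone. Compound 4 is therefore expected to lose some potency, with the step of a 3.2-fold higher number from compound 2 to compound 4 (0.51 log units; beyond the scatter) being the estimate. Compound 4 is estimated at 250 nM in this assay, within a range from 60 nM to 1200 nM.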

Compound 4, half-maximal inhibitory concentration: 120 nM
Compound 4: middle estimate off by 2.1-fold (0.32 log units), on the high side, within the range that was stated.
By their numbers in this assay, from the lowest: compounds 2 and 4 (each within the scatter of the next); then compound 1; then compound 3.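

In this assay, the step of a 1.5-fold higher number from compound 2 to compound 4 (0.19 log units; within the scatter) leaves the two compounds indistinguishable, so with the 4,4-difluoropiperidin-1-yl amide in place, this position on the sulfonyl sulfur accepts either the cyclobutyl ring or the open diethylamino group. With the diethylsulfamoyl group held constant, the large differences appear on the amide side, as a 71-fold lower number from compound 3 to compound 4 (1.85 log units; beyond the scatter) and a 17-fold lower number from compound 1 to compound 4 (1.22 log units; beyond the scatter) show, so the weak numbers of compounds 1 and 3 track their amide groups rather than this sulfonyl substituent. No measurement offered here explains why either swap behaves as it does.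

From the compounds shown here alone, it remains open whether a methyl or a phenyl group on the same sulfur would also fit. The compounds shown also leave open whether cyclobutyl and diethylamino would match as closely alongside the (4-methoxycyclohexyl)amino or (oxan-4-yl)amino group.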